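From acetyl to a larger fluorine-bearing group

This account rests on a few compounds, and the source may have more. Where it says the series, first, only, none or still open, it means among the compounds named here.

Going by the values given here, in a functional assay on DU-145 cells (Homo sapiens) for cytotoxicity, read by sulforhodamine B assay, with a stated time of 48 h (a higher number here means a weaker inhibitor, a lower number a stronger inhibitor), compound 1 `CC(=O)OC[C@H]1O[C@@H](n2cc(Cn3cc(C(C)=O)c4ccccc43)nn2)[C@H](OC(C)=O)[C@@H](OC(C)=O)[C@@H]1OC(C)=O` gives 75200 nM, the only exact number so far. Compound 2 `CC(=O)OC[C@H]1O[C@@H](n2cc(Cn3cc(/C=C4/C(=O)Nc5ccccc54)c4ccccc43)nn2)[C@H](OC(C)=O)[C@@H](OC(C)=O)[C@@H]1OC(C)=O` shows > 200000 nM, which is a limit of the assay and not a number. Compound 3 `CC(=O)OC[C@H]1O[C@@H](n2cc(Cn3cc(/C=C4/C(=O)Nc5ccc(F)cc54)c4ccccc43)nn2)[C@H](OC(C)=O)[C@@H](OC(C)=O)[C@@H]1OC(C)=O` carries this change: a group of 12 heavy atoms (9 carbon, 1 nitrogen, 1 oxygen, 1 fluorine; one five-membered non-aromatic ring with 1 hetero atom, one six-membered aromatic ring of carbon only) in place of a group of 3 heavy atoms (2 carbon, 1 oxygen; no ring), on an aromatic carbon. Among the compounds with values here, the one measured step that bears on it, an at least 2.6-fold higher number from compound 1 to compound 2 (0.42 log units; beyond the scatter), brought in a similar group without the fluorine, and the number rose. A similar rise, meaning a weaker inhibitor, is therefore expected: a 2.1-fold higher number from compound 1 to compound 3 (0.33 log units; beyond the scatter). Compound 3 is estimated at 160000 nM, with an expected range of 50000 nM to 400000 nM.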

Compound 3, half-maximal inhibitory concentration: 87400 nM
The estimate for compound 3 lay 1.8-fold (0.26 log units) above the measured number, and the stated range covers the measured number.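

In this assay, the large fluorine-bearing group on this aromatic carbon does not separate from acetyl, with a 1.2-fold higher number from compound 1 to compound 3 (0.07 log units; within the scatter). A single fluoro in place of hydrogen on the larger group does register, with an at least 2.2-fold lower number from compound 2 to compound 3 (0.35 log units; beyond the scatter), so the size of the group alone does not set the number. Compound 2 stands at a limit and not a number, so that step gives only a minimum size: the limit of > 200000 nM in this assay, at which 1 of the 3 values shown sits.

As far as these compounds go, whether chloro or methoxy in place of the fluoro would act the same way stays open, as does how an amine on this aromatic carbon would compare with acetyl.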